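The source may report more compounds than this note shows. Statements on the series, on what has been measured and on what is new or still open speak of the compounds shown alone.

Measured compounds in the series:

Compound 1, `COc1ccc(-c2cc(/C=C/C(=O)c3ccc(N)cc3)[nH]n2)cc1`: 1210 nM
Compound 2, `COc1ccc(-c2cc(/C=C/C(=O)c3ccc(N)cc3)[nH]n2)cc1OC`: 1650 nM
Compound 3, `COc1cc(C(=O)/C=C/c2cc(-c3cc(OC)c(OC)c(OC)c3)n[nH]2)cc(OC)c1OC`: 520 nM

In a functional assay on NCI-H522 cells (Homo sapiens) for inhibition, read by sulforhodamine B assay, with a stated time of 48 h (a lower number here means a stronger inhibitor of growth, a higher number a weaker inhibitor of growth), compound 3 gives the lowest number of the three, with compound 1 nearest at a gap beyond the scatter and compound 2 furthest, also beyond the scatter. Compound 3 and compound 2 share a related framework, but the difference between the two cores is not broken down here.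

Compound 2 and compound 1 differ in one place: hydrogen in place of methoxy on an aromatic carbon. The step of a 1.4-fold lower number from compound 2 to compound 1 (0.13 log units; within the scatter) is within the scatter, so the two values show no real separation in this assay.

Compound 4, `COc1ccc(-c2cc(/C=C/C(=O)c3cc(OC)c(OC)c(OC)c3)[nH]n2)cc1OC`, has not yet been measured in this assay. It differs from compound 3 in one place: hydrogen in place of methoxy on an aromatic carbon. The surroundings of that place are not word for word the same as for compound 2 to compound 1; in compound 3 the carbon is also meta to a methoxy group, so this is the same kind of change rather than the same change.

The expectation for compound 4 rests on compound 3 giving 520 nM and on the earlier step of a 1.4-fold lower number from compound 2 to compound 1 (0.13 log units; within the scatter) being within the scatter. Compound 4 is therefore expected to show a step of about a 1.2-fold lower number from compound 3 to compound 4 (0.06 log units; within the scatter), with the number staying close to that of its parent. The estimate for compound 4 is 450 nM, expected to fall between 200 nM and 1000 nM.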

Compound 4, concentration for 50% growth inhibition: 1330 nM
Beside the measured number, compound 4's estimate is 3.0-fold (0.47 log units) below it; measured number outside the range, above it.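

In this assay, hydrogen in place of methoxy on an aromatic carbon gives a 2.6-fold higher number from compound 3 to compound 4 (0.41 log units; beyond the scatter), and this step does not match the one seen on the other core: the same change on two cores in this assay, a 1.4-fold lower number (0.13 log units; within the scatter) from compound 2 to compound 1 and a 2.6-fold higher number (0.41 log units; beyond the scatter) from compound 3 to compound 4, 3.5-fold (0.54 log units) apart, beyond the scatter of two such steps

The same change therefore cannot be carried as a fixed increment between these two cores; a step that stays within the scatter on one core gives no assurance of the same on the other. Two pairs do not show which part of the cores accounts for the difference, and they give no rule for any further core in the series.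

Open, going by these compounds, is whether the loss seen from the methoxy group on the core of compound 3 is specific to methoxy, which a hydroxyl, ethoxy group or fluorine at the same place on that core would help to settle. Also open, on these data alone, is whether the two cores would keep their different responses to this change if the amine of compound 1 and compound 2 were replaced by an amide or a dimethylamino group.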